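Swapping a hydroxy for an acetyl on the aryl ring

The source may hold more compounds than are shown below. What is called first, only, known or untested is meant among the compounds shown, and "the series" means these compounds.

Compound 2, drawn as `CC1CC/C(=N\Nc2ccc(O)cc2)c2ncc(C(=O)O)c(=O)n21`, is measured in a functional assay on the whole organism for inhibition, with Rattus norvegicus as the target (a lower number here means that less compound is needed, a higher number that more compound is needed for the effect), and gives 1.7 umol/kg. That is the lowest of the three numbers shown. Compound 1, `CC1CC/C(=N\Nc2ccccc2F)c2ncc(C(=O)O)c(=O)n21`, gives 5 umol/kg in this assay, and the step of a 2.9-fold lower number from compound 1 to compound 2 (0.47 log units; beyond the scatter) shows that putting 4-hydroxyphenyl in place of 2-fluorophenyl on the amine nitrogen lowered the dose by a modest amount. Compound 3, `C[C@H]1CC/C(=N\Nc2ccc(O)cc2)c2ncc(C(=O)O)c(=O)n21`, gives 111 umol/kg, and the step of a 65-fold higher number from compound 2 to compound 3 (1.81 log units; beyond the scatter) is large; it rests on (the fact that one of compounds 2 and 3 is drawn with a defined configuration and the other without, at the place where they differ), and so concerns the ring carbon rather than the aromatic ring.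

The new compound 4, `CC(=O)c1ccc(N/N=C2\CCC(C)n3c2ncc(C(=O)O)c3=O)cc1`, differs from compound 2 by acetyl in place of hydroxy on an aromatic carbon. Among the compounds with values here, only the step from compound 1 to compound 2 touches the same part of the molecule, and it was modest. The change from hydroxy to acetyl removes the hydrogen-bond donor, so a step of similar modest size is expected, most likely towards a somewhat higher number, though a result within the scatter cannot be excluded. The expected step is a 2.4-fold higher number from compound 2 to compound 4 (0.37 log units; beyond the scatter). Compound 4 is therefore estimated to give 4 umol/kg in this assay, with a likely range from 1.5 umol/kg to 12 umol/kg.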

Compound 4, dose for 50% inhibition: 9.5 umol/kg
Compound 4: middle estimate off by 2.4-fold (0.38 log units), on the low side; the range from low to high includes it.
By their numbers in this assay, from the lowest: compound 2; then compounds 1 and 4 (each within the scatter of the next); then compound 3.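

What this adds is a direct reading of the substituent at this one place on the aryl ring, para to a large group, with everything else held constant. The earlier step from compound 1 to compound 2 changed both the substituent and where it sits, whereas a 5.6-fold higher number from compound 2 to compound 4 (0.75 log units; beyond the scatter) in this assay isolates hydroxy against acetyl, showing that this place responds to the group it carries and that hydroxy is the better of the two here. The change is still modest, far smaller than a 65-fold higher number from compound 2 to compound 3 (1.81 log units; beyond the scatter) at the ring carbon, and nothing shown explains why acetyl needs the higher dose.

Acetyl differs from hydroxy in two ways at once, since it adds heavy atoms and has no hydrogen-bond donor, so these compounds cannot say which difference matters; an amine or a methoxy group at the same place would help to separate the two. On these data alone, compound 4 is also drawn without a configuration at the ring carbon, so how its two mirror-image forms would compare remains open.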